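Changing the benzyl group in a series at the assay limit

A few compounds are considered here, and "the series" means these few. Any claim that something is new, unique, unknown or untested is made for them only; others in the source may bear on it.

Compound 1 (`Cc1ccc(/C=C2\CN(C(=S)SCc3cn(Cc4cccc(Cl)c4)nn3)C/C(=C\c3ccc(C)cc3)C2=O)cc1`) reads > 80000 nM in a functional assay on PC-3 cells (Homo sapiens) for cytotoxicity, read by MTT assay, with a stated time of 24 h (a lower number here means a stronger inhibitor, a higher number a weaker inhibitor), as a limit of the assay, not a number. Compound 2 (`O=C1/C(=C/c2ccccc2F)CN(C(=S)SCc2cn(Cc3ccccc3F)nn2)C/C1=C\c1ccccc1F`) reads > 80000 nM in this assay and likewise stands as a limit only. Within the data shown here, no measured step is available.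

Compound 3 (`O=C1/C(=C/c2ccccc2F)CN(C(=S)SCc2cn(Cc3cccc(Cl)c3)nn2)C/C1=C\c1ccccc1F`) differs from compound 2 on a saturated chain carbon bound to an aromatic nitrogen, where 3-chlorophenyl replaces 2-fluorophenyl (3-chlorophenyl in place of 2-fluorophenyl on a saturated chain carbon bound to an aromatic nitrogen). Among the measured compounds shown here, compound 1 already carries 3-chlorobenzyl and shares with compound 2 the limit of > 80000 nM in this assay, at which 2 of the 2 values shown sit, as its only reading, so this change gives no reason to expect a clear gain. The estimated a number no higher from compound 2 to compound 3 (the limit leaves the size open) is expected to stay within the scatter, in no set direction. For compound 3 the estimate is 80000 nM with an expected range from 30000 nM to 160000 nM in this assay, and another limit reading is the likeliest outcome.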

Compound 3, half-maximal inhibitory concentration: 80000 nM
Beside the measured number, compound 3's estimate shows no gap at the digits printed; measured number inside the range.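

In this assay compound 3 gives 80000 nM, the only plain number among the compounds shown. Compound 2 reads > 80000 nM, which is a limit of the assay. The step is a number no higher from compound 2 to compound 3 (the limit leaves the size open), so going from 2-fluorobenzyl to 3-chlorobenzyl at this position gives a direction at most and no readable size, and the series stays tied to the top of the assay's range: the limit of > 80000 nM in this assay, at which 2 of the 3 values shown sit.

From the compounds shown here alone, whether any group on this saturated chain carbon bound to an aromatic nitrogen can bring a reading clearly below that level remains open. An amine or a carboxylic acid on the phenyl ring, or a longer chain in place of the benzyl group, would test this position more sharply than another halogen swap.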